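Swapping the Amide Aryl Group for an Imidazole

This account rests on a few compounds, and the source may have more. Where it says the series, first, only, none or still open, it means among the compounds named here.

Among the compounds with values here, in an ADME assay on microsomes from liver (Mus musculus) for metabolic stability (a higher number here means that the compound lasts longer, a lower number that the compound disappears faster), compound 1 `COc1ccc(-c2cnc(NC(=O)c3ccc(F)cc3)n2C)cc1` gives 0.0667 h, the lowest of the two numbers measured so far, while compound 2 `Cn1c(-c2cccc(Cl)c2)cnc1NC(=O)c1ncc[nH]1` gives 1.37 h, a gap beyond the usual scatter. Compound 3 `COc1ccc(-c2cnc(NC(=O)c3ncc[nH]3)n2C)cc1` arises from compound 1 by a single change: 1H-imidazol-2-yl in place of 4-fluorophenyl on a carbonyl carbon. Within the data shown here, no measured pair isolates this change on its own. Because compound 2 gives 1.37 h with the same 1H-imidazol-2-yl group on its carbonyl carbon, the step of a 9.0-fold higher number from compound 1 to compound 3 (0.95 log units; beyond the scatter) is expected to run upward, though compound 2 also differs elsewhere. Compound 3 is therefore estimated at 0.6 h, within a range of 0.15 h to 2 h.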

Compound 3, half-life in the Mus musculus assay: 0.05 h
The estimate for compound 3 lay 12-fold (1.08 log units) above the measured number, and the stated range ends above it.
By their numbers in the Mus musculus assay, from the lowest: compounds 3 and 1 (each within the scatter of the next); then compound 2.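

Set on the carbonyl carbon of the core of compound 1, 1H-imidazol-2-yl in place of 4-fluorophenyl gives no gain in the Mus musculus assay: a 1.3-fold lower number from compound 1 to compound 3 (0.13 log units; within the scatter). In a physicochemical assay for solubility, read by nephelometry, measured as kinetic solubility, at pH 6.5 (a lower number here means a less soluble compound, a higher number a more soluble compound), compound 1 gives < 1.6 ug/mL, a limit of the assay, and the step from it can be read only as a minimum because of that: the limit of < 1.6 ug/mL in the physicochemical assay, at which 1 of the 2 values shown sits. In the physicochemical assay compound 3 gives 6.3 ug/mL, which makes an at least 3.9-fold higher number from compound 1 to compound 3 (0.59 log units; beyond the scatter).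

Still open, going by these compounds, is whether another group on that carbonyl carbon, such as a pyridine ring or a morpholine, would give a longer half-life in the Mus musculus assay while matching the solubility of compound 3.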